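Fluoro to trifluoromethyl on the chloro-bearing ring

A few compounds are considered here, and "the series" means these few. Any claim that something is new, unique, unknown or untested is made for them only; others in the source may bear on it.

Compound 1 `O=C(Nc1ccc(Oc2ccnc3[nH]ccc23)c(F)c1)c1nn(-c2ccc(Cl)cc2)ccc1=O`: > 60000 nM (a limit of the assay, not a number).
Compound 2 `O=C(Nc1ccc(Oc2ccnc3[nH]ccc23)c(F)c1)c1nn(-c2ccccc2)ccc1=O`: 24900 nM.
Compound 3 `O=C(Nc1ccc(Oc2ccnc3[nH]ccc23)c(F)c1)c1nn(-c2ccc(Cl)c(F)c2)ccc1=O`: 9610 nM.

In a functional assay on HepG2 cells (Homo sapiens) for cytotoxicity, read by MTT assay, with a stated time of 72 h (a higher number here means a weaker inhibitor, a lower number a stronger inhibitor), compound 3 has the lowest of the two numbers given; the nearest is compound 2, with the step of a 2.6-fold lower number from compound 2 to compound 3 (0.41 log units; beyond the scatter). Compound 1 gives only the limit (the limit of > 60000 nM in this assay, at which 1 of the 3 values shown sits). Compound 4 `O=C(Nc1ccc(Oc2ccnc3[nH]ccc23)c(F)c1)c1nn(-c2ccc(Cl)c(C(F)(F)F)c2)ccc1=O` differs from compound 3 in one place: trifluoromethyl in place of fluoro on an aromatic carbon. Of the measured steps, an at least 2.4-fold lower number from compound 1 to compound 2 (0.38 log units; beyond the scatter) and an at least 6.2-fold lower number from compound 1 to compound 3 (0.79 log units; beyond the scatter) touch the same ring, and a 2.6-fold lower number from compound 2 to compound 3 (0.41 log units; beyond the scatter) added the chloro and fluoro together; all three are modest and downward. A modest downward step or none beyond the scatter is therefore expected, a 1.5-fold lower number from compound 3 to compound 4 (0.17 log units; within the scatter). Compound 4 is estimated at 6500 nM, in the range 2500 nM to 17000 nM.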

Compound 4, half-maximal inhibitory concentration: 11900 nM
Beside the measured number, compound 4's estimate is 1.8-fold (0.26 log units) below it; the range from low to high includes it.
By their numbers in this assay, from the lowest: compounds 3 and 4 (each within the scatter of the next); then compound 2. At a limit, above all of these: compound 1.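

In this assay, swapping fluoro for the larger trifluoromethyl, ortho to a chloro group, gives no change beyond the scatter: a 1.2-fold higher number from compound 3 to compound 4 (0.09 log units; within the scatter). So this position accepts either group, and the modest difference from the unsubstituted phenyl remains: a 2.1-fold lower number from compound 2 to compound 4 (0.32 log units; beyond the scatter). Compound 1, with hydrogen at this position, has only a limit of the assay and not a number, so its step is a bound: an at least 5.0-fold lower number from compound 1 to compound 4 (0.70 log units; beyond the scatter).

On these data alone, whether a methoxy group, an amine or a carboxylic acid here would fit the same flat picture remains open. As far as these compounds go, how far compound 1 truly lies from the others also remains open.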